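Arylpiperazine oxindoles: swapping the aryl group on compound 2

The source may report more compounds than this note shows. Statements on the series, on what has been measured and on what is new or still open speak of the compounds shown alone.

Three compounds with a shared oxindole core carrying a four-carbon chain to a cyclic amine have been measured in an assay on CHO cells for displacement of a labelled ligand from 5-hydroxytryptamine receptor 7 (Homo sapiens); a lower number here means a stronger inhibitor, a higher number a weaker inhibitor. Compound 1 `CCC1(CCCCN2CC=C(c3ccc(F)cc3)CC2)C(=O)Nc2ccccc21`, which bears a tetrahydropyridine, gives 1.19 nM. Compound 2 `CCC1(CCCCN2CCN(c3ccc(C)c(Cl)c3)CC2)C(=O)Nc2ccccc21`, with a piperazine bearing 3-chloro-4-methylphenyl, gives 0.66 nM. Compound 3 `O=C1Nc2ccccc2C1CCCCN1CCN(c2cccc(Cl)c2)CC1`, which lacks the ethyl group on the core and carries a 3-chlorophenyl piperazine, gives 0.49 nM. Compound 2 stands with its number between the other two: compound 3 is nearest and compound 1 furthest, and both gaps lie within the scatter, so no order among the three can be read from these numbers.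

Compound 4 `CCC1(CCCCN2CCN(c3ccc(F)cc3)CC2)C(=O)Nc2ccccc21` has not yet been measured. It differs from compound 2 in one place: 4-fluorophenyl in place of 3-chloro-4-methylphenyl on an amine nitrogen in a ring. The 4-fluorophenyl group already appears in compound 1, there on a tetrahydropyridine rather than a piperazine, and compound 1 gives 1.19 nM.

For the measured compounds named here, no step between two measured compounds isolates this change. For the step from compound 2 to compound 4 in this assay a small upward movement is expected, not clearly beyond the scatter, because compound 1 with the same aryl group gives 1.19 nM. Compound 4 is therefore estimated at 1.2 nM, with a range from 0.4 nM to 4 nM, the expected step being a 1.8-fold higher number from compound 2 to compound 4 (0.26 log units; within the scatter).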

Compound 4, inhibition constant: 0.43 nM
Beside the measured number, compound 4's estimate is 2.8-fold (0.45 log units) above it; low and high end bracket the measured number.
By their numbers in this assay, from the lowest: compounds 4, 3, 2 and 1 (each within the scatter of the next, the first and the last beyond it).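

In this assay the aryl group on the piperazine nitrogen is now isolated in a single step, and 4-fluorophenyl in place of 3-chloro-4-methylphenyl gives a 1.5-fold lower number from compound 2 to compound 4 (0.19 log units; within the scatter) on this otherwise unchanged scaffold. This position, on an amine nitrogen in a ring, therefore accepts either of these two aryl groups with no movement that can be told from the scatter, so the chlorine and methyl of compound 2 are not shown to be needed here. The 4-fluorophenyl group also does not fix the number on its own: compound 4, with a piperazine, gives 0.43 nM as its value and compound 1, with a tetrahydropyridine, gives 1.19 nM as its value, and these two stand furthest apart among the four numbers, beyond the scatter of each other.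

Going by these compounds, it remains open whether a plain phenyl, a pyridyl or a phenyl bearing a carboxylic acid on the same nitrogen would stay within this narrow spread of numbers, and whether the same exchange behaves alike on a core without the ethyl group. Nothing measured here gives a reason for the result.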